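Compound 2 and Its Methoxycarbonyl Counterpart, Compound 3

The source may report more compounds than this note shows. Statements on the series, on what has been measured and on what is new or still open speak of the compounds shown alone.

compound 1 `CCCCCCCCCC(O)CNC(C)=O`: "not active" (no number reported)
compound 2 `CCCCCCCCCC(O)CN`: 3880 nM

For the measured compounds named here, in a functional assay on MCF7 cells (Homo sapiens) for cytotoxicity, read by MTT assay (a lower number here means a stronger inhibitor, a higher number a weaker inhibitor), compound 2 gives 3880 nM, and this is the only number available. Compound 1 is recorded as "not active" (no number reported), with no number to set beside it, so compound 2 cannot be placed on any wider scale.

The next compound to be tested is compound 3 `COC(=O)CCCCCCCCC(O)CN`. Its structure departs from that of compound 2 as follows: methoxycarbonyl in place of methyl on a saturated chain carbon, nine bonds along the chain from an oxygen on a saturated carbon. In words, methoxycarbonyl stands in place of methyl on a saturated chain carbon, nine bonds along the chain from an oxygen on a saturated carbon.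

Going by the values given here, no measured pair shows what this change does, so any forecast is tentative and starts from the value of compound 2 at 3880 nM. A moderate move towards weaker inhibition seems the likeliest outcome, and a result with no number remains possible. The expected size of the change is a 3.1-fold higher number from compound 2 to compound 3 (0.49 log units; beyond the scatter). For compound 3 the estimated value in this assay is 12000 nM, with an expected range from 4000 nM to 40000 nM.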

Compound 3, half-maximal inhibitory concentration: 10200 nM
Compound 3: the middle estimate sits 1.2-fold (0.07 log units) above what was measured, within the range that was stated.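

In this assay, for the compounds shown here, methoxycarbonyl in place of methyl on a saturated chain carbon, nine bonds along the chain from an oxygen on a saturated carbon, gives a 2.6-fold higher number from compound 2 to compound 3 (0.42 log units; beyond the scatter), the first step in this set that can be read as a number. The far end of the chain can therefore carry this larger group while the compound still gives a numerical value, although the modest step runs towards weaker inhibition. No measurement shown here bears on why the step has this direction or size.

The compounds shown leave open whether this step belongs to the methoxycarbonyl group itself or would also follow from a longer chain ending in a plain methyl group, and a carboxylic acid in the same place would test whether the methyl of the ester matters. From the compounds shown here alone, it also remains open how the same replacement would behave with the acetyl group of compound 1 on the amine, since that compound gives no number against which a step could be read.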